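The compounds below may be only part of what the source reports. "The series", "measured", "known", "first", "only" and "open" are said of these compounds alone.

Compound 3 `CC(C)[C@H](NC(=O)c1cc(Cl)ccc1O)C(=O)Nc1ccc(Cl)c(Cl)c1` gives only a limit in a functional assay on MCF7 cells (Homo sapiens) for cytotoxicity, with a stated time of 72 h; a lower number here means a stronger inhibitor, a higher number a weaker inhibitor: compound 3 reads > 10000 nM. The two measured steps into it cannot be sized. Compound 1 `CC(C)[C@H](NC(=O)c1cc(Cl)ccc1O)C(=O)Nc1ccc(Cl)cc1` also gives a limit; in this assay compound 1 reads > 10000 nM. Compound 2 `CC(C)[C@H](NC(=O)c1ccc(Cl)cc1O)C(=O)Nc1ccc(Cl)c(Cl)c1` likewise gives a limit, reading > 10000 nM in this assay. Thus a step that the two limits leave unreadable from compound 1 to compound 3 and a step that the two limits leave unreadable from compound 2 to compound 3 remain unreadable because of the limit of > 10000 nM in this assay, at which 3 of the 3 values shown sit. Compound 4 `CC(C)[C@H](NC(=O)c1cc(Cl)ccc1O)C(=O)Nc1ccccc1` differs from compound 3 by phenyl in place of 3,4-dichlorophenyl on an amide-type nitrogen. Among the compounds with values here, no measured step mirrors this change, and nothing among the three compounds places any value beneath the limit. Compound 4 is therefore expected to give about 30000 nM in this assay, between 10000 nM and 100000 nM, most likely again only as a limit. The step that the limit leaves unreadable from compound 3 to compound 4 is expected to be no step beyond the scatter.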

Compound 4, half-maximal inhibitory concentration: > 10000 nM
Compound 4 gave a limit, no number (the forecaster's own chance of this, stated with the estimate: 85%); the middle value does not contradict the limit.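

Compound 4 also gives only a limit, so neither the step from compound 1 to compound 4 nor the step from compound 3 to compound 4 can be read in this assay: the limit of > 10000 nM in this assay, at which 4 of the 4 values shown sit. The compounds shown leave open which change, if any, would bring a value beneath that limit.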